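Two Dichlorophenyl Regioisomers on a Carbamate Scaffold

A few compounds are considered here, and "the series" means these few. Any claim that something is new, unique, unknown or untested is made for them only; others in the source may bear on it.

The series here rests on a benzylcarbamate joined through a saturated carbon to an aryloxy group, and it is followed in an assay for inhibition of zeta-carotene desaturase, chloroplastic/chromoplastic (Capsicum annuum), using a Dixon plot, with a stated time of 8 h; on this read-out higher numbers stand for weaker inhibition and lower numbers for stronger inhibition. Compound 1 `CCC(COc1cccc(Cl)c1)OC(=O)NCc1ccccc1` carries a 3-chlorophenyl on that oxygen. In this assay compound 1 gives only a limit, > 100000 nM. Compound 2 `CCC(COc1c(Cl)cccc1Cl)OC(=O)NCc1ccccc1` carries a 2,6-dichlorophenyl instead. In this assay compound 2 likewise gives only a limit, > 100000 nM. The step that the two limits leave unreadable from compound 1 to compound 2 therefore cannot be read; both values sit at the same limit, as summarised by the limit of > 100000 nM in this assay, at which 2 of the 2 values shown sit.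

Compound 3 `CCC(COc1ccc(Cl)c(Cl)c1)OC(=O)NCc1ccccc1` is the next member, and it differs from compound 2 in a single place: 3,4-dichlorophenyl in place of 2,6-dichlorophenyl on an oxygen on a saturated carbon. Among the measured compounds shown here, the one measured step, from compound 1 to compound 2, bears on this change only loosely, since it too moves the chlorine pattern on the aryloxy ring, and it gives no readable size. With both neighbours at the limit, compound 3 is expected to stay there as well, so the expected step that the limit leaves unreadable from compound 2 to compound 3 is none beyond the scatter. Compound 3 is accordingly estimated at 150000 nM, within a range from 40000 nM to 600000 nM.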

Compound 3, half-maximal inhibitory concentration: > 100000 nM
Compound 3 gave a limit, no number; the forecaster's own chance of this, stated with the estimate: 80%; the middle value lies beyond the limit too.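

In this assay compound 3 also gives only a limit, > 100000 nM. Among the compounds shown here, no step among compound 1, compound 2 and compound 3 can be read, since all three stand at one limit: the limit of > 100000 nM in this assay, at which 3 of the 3 values shown sit. The compounds shown leave open whether the chlorine pattern on the aryloxy ring affects inhibition at all.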